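Nitro to acetamidomethyl: a step without precedent

This account rests on a few compounds, and the source may have more. Where it says the series, first, only, none or still open, it means among the compounds named here.

In a functional assay on HT-1080 cells (Homo sapiens), read by transwell migration, with a stated time of 24 h, tested at 1 uM (on this read-out higher numbers stand for a weaker effect at the one concentration tested and lower numbers for a stronger effect), compound 1 `O=C(Oc1ccccc1)c1cc2cc([N+](=O)[O-])ccc2oc1=O` gives 76.7%, the highest of the three numbers measured, so its effect is the weakest of the three. Compound 2 `O=C(Oc1cccc(F)c1)c1cc2cc([N+](=O)[O-])ccc2oc1=O` gives 53.6% and compound 3 `O=C(Oc1cccc(Cl)c1)c1cc2cc([N+](=O)[O-])ccc2oc1=O` gives 65.8%; the steps of a number 23.1 percentage points lower from compound 1 to compound 2 (beyond the scatter) and a number 10.9 percentage points lower from compound 1 to compound 3 (beyond the scatter) both strengthen the effect, while a number 12.2 percentage points higher from compound 2 to compound 3 (beyond the scatter) weakens it. Those halogen changes touch a different part of the shared core than the change to compound 4 `CC(=O)NCc1ccc2oc(=O)c(C(=O)Oc3ccccc3)cc2c1`, which differs from compound 1 by acetamidomethyl in place of nitro on an aromatic carbon. Among the compounds with values here, no measured step concerns that place, so neither size nor direction can be drawn from them. Compound 4 is therefore expected to stay near compound 1, at 70% within 45% to 95%, an expected step of a number 6.7 percentage points lower from compound 1 to compound 4 (within the scatter) that may well lie within the scatter.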

Compound 4, a percentage reported as activity, at one concentration (the size of the read-out at that concentration, not a potency): 63.5%
The estimate for compound 4 lay 6.5 percentage points above the measured number, within the range that was stated.
By their numbers in this assay, from the lowest: compounds 2, 4 and 3 (each within the scatter of the next, the first and the last beyond it); then compound 1.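

In this assay, this place on the shared core does not depend on nitro: acetamidomethyl takes its place with a number 13.2 percentage points lower from compound 1 to compound 4 (beyond the scatter), so the effect grows stronger rather than being lost. One pair cannot show which feature of the new group matters, and nothing measured here explains the step.

As far as these compounds go, it remains open how an amine or a carboxylic acid would behave at this place. Also open, from the compounds shown here alone, is whether the fluoro of compound 2 and the acetamidomethyl of compound 4 would add up in one molecule.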